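The source may report more compounds than this note shows. Statements on the series, on what has been measured and on what is new or still open speak of the compounds shown alone.

Measured so far in a functional assay on T47D cells (Homo sapiens) for inhibition, read by sulforhodamine B assay, with a stated time of 48 h; on this read-out higher numbers stand for weaker inhibition of growth and lower numbers for stronger inhibition of growth:
compound 1, `C=C(C/C(=C\c1ccc(Cl)cc1)C(=O)c1ccccc1)C(=O)c1ccccc1`, 19000 nM
compound 2, `C=C(C/C(=C\c1ccccc1F)C(=O)c1ccccc1)C(=O)c1ccccc1`, 14000 nM

Compound 2 stands lowest of the two numbers in this assay, but its nearest neighbour is compound 1 and the gap between them is within the scatter, so the two values cannot be ordered against each other. Compound 3, `C=C(C/C(=C\c1ccc(OC)cc1)C(=O)c1ccccc1)C(=O)c1ccccc1`, has not yet been measured in this assay. It differs from compound 2 in one place: 4-methoxyphenyl in place of 2-fluorophenyl on a double-bonded chain carbon bound to a double-bonded chain carbon. Among the measured compounds shown here, the only measured step that bears on a change of this kind, an exchange of one aryl group for another at the same place, is a 1.4-fold lower number from compound 1 to compound 2 (0.13 log units; within the scatter), which lies within the scatter and therefore gives no direction. For the measured compounds named here, no measured compound carries a 4-methoxyphenyl at this place, so there is no direct precedent for the entering group. On this basis the step expected in this assay is none beyond the scatter, a 1.1-fold higher number from compound 2 to compound 3 (0.06 log units; within the scatter). Compound 3 is accordingly estimated at 16000 nM, with a range from 6000 nM to 42000 nM.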

Compound 3, concentration for 50% growth inhibition: 370 nM
Beside the measured number, compound 3's estimate is 43-fold (1.64 log units) above it; the whole stated range lies above it.
By their numbers in this assay, from the lowest: compound 3; then compounds 2 and 1 (each within the scatter of the next).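

Notes on the group on the double-bonded chain carbon, in this assay: the earlier exchange of aryl groups here gave no sign that this place matters, since the step of a 1.4-fold lower number from compound 1 to compound 2 (0.13 log units; within the scatter) lies within the scatter. The step of a 38-fold lower number from compound 2 to compound 3 (1.58 log units; beyond the scatter) now shows that an aryl exchange at this same place can move the number far beyond the scatter, towards stronger inhibition of growth. The step of a 51-fold lower number from compound 1 to compound 3 (1.71 log units; beyond the scatter) is of the same large order and shows that methoxy in place of chloro on an aromatic carbon is enough on its own to produce such a change, while no measurement available here bears on the reason for it.

Open, going by these compounds, is whether the large step is particular to methoxy or would also appear with a hydroxy, an ethoxy or a dimethylamino group on the same aromatic carbon. On these data alone, the phenyl groups on the two carbonyls are the same in all three compounds, so it is also open whether the step would hold with a methyl or a cyclohexyl group in their place.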